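Removing a Second Aromatic Methyl from Compound 1

The compounds below may be only part of what the source reports. "The series", "measured", "known", "first", "only" and "open" are said of these compounds alone.

Compound 1, `CC/C=C\C/C=C\C/C=C\CCCCCCCc1cc(=O)c2c(O)c(C)c(OCOC)c(C)c2o1`: in a functional assay on MCF7 cells (Homo sapiens) for antiproliferative activity, read by MTT assay (on this read-out higher numbers stand for weaker inhibition and lower numbers for stronger inhibition), compound 1 gives > 84100 nM, which is a limit of the assay.
Compound 2, `CC/C=C\C/C=C\C/C=C\CCCCCCCc1cc(=O)c2c(O)c(C)c(OCOC)cc2o1`: compound 2 gives 17500 nM.
Compound 3, `CCCC/C=C\CCCCCCCCCc1cc(=O)c2c(O)c(C)c(OCOC)c(C)c2o1`: compound 3 gives > 67200 nM, again only a limit.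

Compound 1 therefore stands on the numbers only as a limit, not as a measured value, and the same holds for compound 3. The step from compound 1 to compound 4 is the change (hydrogen in place of methyl on an aromatic carbon). The closest measured step is an at least 4.8-fold lower number from compound 1 to compound 2 (0.68 log units; beyond the scatter), in which a methyl on a different aromatic carbon was replaced by hydrogen. The step that the two limits leave unreadable from compound 1 to compound 3 changes the chain and tells nothing about a methyl. Compound 4, `CC/C=C\C/C=C\C/C=C\CCCCCCCc1cc(=O)c2c(O)cc(OCOC)c(C)c2o1`, is not yet measured. By analogy with compound 2, the step of an at least 3.3-fold lower number from compound 1 to compound 4 (0.52 log units; beyond the scatter) is expected. Compound 4 is estimated at 25000 nM, within 8000 nM to 84000 nM.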

Compound 4, half-maximal inhibitory concentration: 17500 nM
Compound 4: the middle estimate sits 1.4-fold (0.15 log units) above what was measured; the range from low to high includes it.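

Replacing the methyl that sits ortho to the hydroxy group and ortho to the methoxymethoxy group with hydrogen gives an at least 4.8-fold lower number from compound 1 to compound 4 (0.68 log units; beyond the scatter) in this assay. Activity therefore becomes measurable on losing either aromatic methyl, since the other removal gives an at least 4.8-fold lower number from compound 1 to compound 2 (0.68 log units; beyond the scatter). Compound 1 gives only a limit, so the true size of both steps stays unknown: the limit of > 84100 nM in this assay, at which 1 of the 4 values shown sits.

Still open, on these data alone, is how a core carrying neither methyl would behave. Also open, as far as these compounds go, is whether an amine or an ethyl group at this position would match hydrogen.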